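Swapping one side chain on compound 2

The compounds below may be only part of what the source reports. "The series", "measured", "known", "first", "only" and "open" are said of these compounds alone.

In a physicochemical assay for lipophilicity, using the shake flask method, in phosphate buffer, measured as octanol-water partition, with a stated time of 30 min, at pH 7.4 (a lower number here means a more polar compound, a higher number a more lipophilic compound), compound 2 (`Cc1nc(CN(C)C)ccc1-c1cnc(NCc2c(F)ccc3c2CCO3)c2cn[nH]c(=O)c12`) gives 2 and compound 1 (`Cc1nccn1-c1cnc(NCc2c(F)ccc3c2CCO3)c2cn[nH]c(=O)c12`) gives 2.1 with no real difference between them, while compound 3 (`Cc1cc(-c2cnc(NCc3c(F)ccc4c3CCO4)c3cn[nH]c(=O)c23)n(C)n1`) stands clearly apart at 3 on this scale. Compound 4 (`Cc1nc(C(=O)N(C)C)ccc1-c1cnc(NCc2c(F)ccc3c2CCO3)c2cn[nH]c(=O)c12`) differs from compound 2 in one place: dimethylcarbamoyl in place of (dimethylamino)methyl on an aromatic carbon with dimethylcarbamoyl in place of (dimethylamino)methyl on an aromatic carbon. Going by the values given here, no measured step makes this exact swap. Swaps of a whole aromatic group are the nearest guide, with a number 0.10 log units lower from compound 1 to compound 2 (within the scatter) in one case and a number 1.00 log units higher from compound 2 to compound 3 (beyond the scatter) in another. In this assay a small upward move within the usual scatter is expected, estimated as a number 0.20 log units higher from compound 2 to compound 4 (within the scatter) for this narrower change. For compound 4 the estimated value is 2.2 with an expected range from 1.7 to 2.7 on this scale.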

Compound 4, distribution coefficient: 2.1
Beside the measured number, compound 4's estimate is 0.10 log units above it; low and high end bracket the measured number.
By their numbers in this assay, from the lowest: compounds 2, 1 and 4 (each within the scatter of the next); then compound 3.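

With the aromatic group kept and only its side chain exchanged, dimethylcarbamoyl in place of (dimethylamino)methyl gives a number 0.10 log units higher from compound 2 to compound 4 (within the scatter) in this assay. The earlier compounds shown here showed only swaps of a whole aromatic group, whereas this result shows that these two side chains, on the carbon next to the ring nitrogen, read alike on this scale. Nothing available explains this likeness.

The compounds shown leave open whether a carboxylic acid or a longer amine chain at this position would also stay within the scatter. From the compounds shown here alone, whether the same exchange would read alike on a different aromatic group also remains open.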